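The compounds below may be only part of what the source reports. "The series", "measured", "known", "first", "only" and "open" are said of these compounds alone.

The compounds were compared in a functional assay on A-375 cells (Homo sapiens), read by thymidine incorporation; a lower number here means a stronger inhibitor, a higher number a weaker inhibitor. Compound 1 (`CCCCCCCC/C=C\CCCCCCCC(=O)N[C@H]1[C@@H](OCCCCCCCC)O[C@H](CO)[C@@H](O)[C@@H]1O`) gives 6 uM in this assay. Compound 2 (`CCCCC(=O)N[C@H]1[C@@H](OCCc2ccccc2)O[C@H](COCC(CO)(CO)COS(=O)(=O)O)[C@@H](O)[C@@H]1O`) gives 9.3 uM in this assay. Compound 3 (`CCCCC(=O)N[C@H]1[C@@H](OCCc2ccccc2)O[C@H](COCC(CO)(CO)CO)[C@@H](O)[C@@H]1O`) reaches only a limit of this assay, > 50 uM, which is the limit of > 50 uM in this assay, at which 1 of the 3 values shown sits. Compound 2 and compound 3 differ in one place: sulfo in place of hydrogen on an oxygen on a saturated carbon. That change made a step in this assay: an at least 5.3-fold lower number from compound 3 to compound 2 (0.73 log units; beyond the scatter). The values of compound 1 and compound 2 lie within the scatter of each other. The difference between the core of compound 1 and the core of compound 3 is not broken down here.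

The unmeasured compound 4 (`CCCCCCCC/C=C\CCCCCCCC(=O)N[C@H]1[C@@H](OCCCCCCCC)O[C@H](CO)[C@@H](O)[C@@H]1OS(=O)(=O)O`) carries the same kind of change relative to compound 1: sulfo in place of hydrogen on an oxygen on a saturated carbon. The surroundings are not identical, though: in compound 2 the oxygen sits on a saturated carbon whose other neighbour is a saturated chain carbon, whereas in compound 4 that carbon's other neighbour is a saturated ring carbon. An improvement is expected for compound 4 because an at least 5.3-fold lower number from compound 3 to compound 2 (0.73 log units; beyond the scatter) was at least modest. As far as these compounds go, that earlier step rests on a limit, so its true size is unknown, and compound 1 already sits at the lowest of the two numbers; for compound 4 the expected step is therefore kept moderate, a 3.0-fold lower number from compound 1 to compound 4 (0.48 log units; beyond the scatter). Compound 4 is estimated at 2 uM in this assay, most likely between 0.6 uM and 8 uM.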

Compound 4, concentration for 50% inhibition: 16 uM
For compound 4 the middle estimate is 8.0-fold (0.90 log units) below the measured one, outside the stated range (above it).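

In this assay, sulfo in place of hydrogen on an oxygen on a saturated carbon gave a 2.7-fold higher number from compound 1 to compound 4 (0.43 log units; beyond the scatter), so the change did not carry over in direction from the earlier pair and did not reproduce its result on the core of compound 1: the same change on two cores in this assay, an at least 5.3-fold lower number (0.73 log units; beyond the scatter) from compound 3 to compound 2 and a 2.7-fold higher number (0.43 log units; beyond the scatter) from compound 1 to compound 4, at least 14-fold (1.15 log units) apart, beyond the scatter of two such steps

As far as these compounds go, the value of compound 3, > 50 uM, is a limit of the assay and not a number, so the true size of the earlier step stays unknown. The two steps show that the outcome of this change depends on its setting in these two pairs, but they do not show which difference sets them apart, whether it is the core, the chains it carries or the place of the sulfo group, and two pairs give no rule for any further core.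

What the compounds shown leave open is whether a phosphate or a carboxylic acid in place of the sulfo group would follow the step seen on the core of compound 1 or the one seen on the core of compound 3. From the compounds shown here alone, it also remains open whether a shorter chain on the core of compound 1 would change the direction of the sulfo step.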